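The compounds below may be only part of what the source reports. "The series", "measured", "known", "first", "only" and "open" are said of these compounds alone.

Measured so far:
compound 1 `COc1ccc(/C=C2\CN(C)C/C(=C\c3ccccc3F)C2=O)cc1OC` in a functional assay on HeLa cells (Homo sapiens) for cytotoxicity, read by MTT assay, with a stated time of 24 h; on this read-out lower numbers stand for stronger inhibition and higher numbers for weaker inhibition: 14400 nM
compound 2 `COc1cc(/C=C2\CN(C)C/C(=C\c3ccccc3F)C2=O)cc(OC)c1OC` in this assay: 3220 nM

Within the data shown here, compound 2 gives the lowest of the two numbers in this assay; the only measured step, a 4.5-fold lower number from compound 1 to compound 2 (0.65 log units; beyond the scatter), concerns a methoxy on the other aryl ring and says nothing about the change now in question. Compound 3 `COc1cc(/C=C2\CN(C)C/C(=C\c3ccc(C#N)cc3)C2=O)cc(OC)c1OC` differs from compound 2 by 4-cyanophenyl in place of 2-fluorophenyl on a double-bonded chain carbon bound to a double-bonded ring carbon. Among the measured compounds shown here, no measured step bears on this exchange, so no step beyond the scatter is expected in this assay, with a wide range. Compound 3 is therefore estimated at 3500 nM (range 1000 nM to 12000 nM), an expected step of a 1.1-fold higher number from compound 2 to compound 3 (0.04 log units; within the scatter).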

Compound 3, half-maximal inhibitory concentration: 3420 nM
Compound 3: the middle estimate sits 1.0-fold (0.01 log units) above what was measured; the measured number falls inside the stated range.
By their numbers in this assay, from the lowest: compounds 2 and 3 (each within the scatter of the next); then compound 1.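

In this assay, 4-cyanophenyl in place of 2-fluorophenyl on a double-bonded chain carbon bound to a double-bonded ring carbon gives a 1.1-fold higher number from compound 2 to compound 3 (0.03 log units; within the scatter). This position therefore accepts this exchange of one substituted phenyl for another with no step beyond the scatter, whereas compound 1 and compound 2 spoke only to a methoxy on the other aryl ring. No measurement on hand accounts for this result.

Since the substituent and its place on the phenyl change together, their separate contributions cannot be read. Going by these compounds, whether an amine, a carboxylic acid or a longer chain at this position would read the same stays open.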